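A few compounds are considered here, and "the series" means these few. Any claim that something is new, unique, unknown or untested is made for them only; others in the source may bear on it.

Compound 1 `O=C(/C=C/c1ccc([N+](=O)[O-])o1)c1ccc(N2CCNCC2)cc1`: > 100000 nM
Compound 2 `O=C(/C=C/c1ccc([N+](=O)[O-])o1)c1ccc(Br)cc1`: > 100000 nM
Compound 3 `Cc1ccccc1C(=O)/C=C/c1ccc([N+](=O)[O-])o1`: 41300 nM

All three share a core and were tested in an ADME assay on Vero cells (Chlorocebus sabaeus) for cytotoxicity, read by resazurin assay, with a stated time of 72 h; on this read-out lower numbers stand for higher toxicity in this test and higher numbers for lower toxicity in this test. For compound 1 the result is not a number but a limit of the assay, > 100000 nM. For compound 2 the result is likewise a limit, > 100000 nM. Going by the values given here, compound 3 is the only one with a definite reading, and in this assay compound 3 gives 41300 nM. Among the compounds with values here, the one pair that differs in a single place is compound 1 and compound 2, where the change is bromo in place of piperazin-1-yl on an aromatic carbon; this step, a step that the two limits leave unreadable from compound 1 to compound 2, cannot be sized, since both values sit at the limit of > 100000 nM in this assay, at which 2 of the 3 values shown sit.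

Compound 4 `CCCCc1ccc(C(=O)/C=C/c2ccc([N+](=O)[O-])o2)cc1` has not yet been measured. It differs from compound 2 by butyl in place of bromo on an aromatic carbon. Within the data shown here, no measured step bears directly on this change, and the one step that does exist is unreadable, so there is no measured basis for expecting a step in either direction beyond the scatter. Compound 4 is therefore estimated to fall near 80000 nM, within a range from 30000 nM to 200000 nM. This amounts to an estimated step of an at least 1.2-fold lower number from compound 2 to compound 4 (0.09 log units; that floor lies within the scatter).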

Compound 4, half-maximal cytotoxic concentration: 75700 nM
The estimate for compound 4 lay 1.1-fold (0.02 log units) above the measured number, within the range that was stated.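

On the aromatic carbon para to a large group, compound 4, which carries butyl, gives a definite reading in this assay, something neither compound 1 nor compound 2 provides, so a change at this position can now be tied to a number at one end. Putting butyl in place of bromo gives an at least 1.3-fold lower number from compound 2 to compound 4 (0.12 log units; that floor lies within the scatter), and putting butyl in place of piperazin-1-yl gives an at least 1.3-fold lower number from compound 1 to compound 4 (0.12 log units; that floor lies within the scatter), so neither step by itself shows a change beyond the usual scatter of the test. Each step is only a floor, since its starting end is not a number but a limit of the assay: the limit of > 100000 nM in this assay, at which 2 of the 4 values shown sit.

As far as these compounds go, how far compound 1 and compound 2 truly lie from compound 4 remains unknown, so either step could be small or large. Also open, from the compounds shown here alone, is whether a longer chain than butyl, an amine or a carboxylic acid at this same place would give a lower or a higher number in this assay than compound 4 does.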